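The source may report more compounds than this note shows. Statements on the series, on what has been measured and on what is new or still open speak of the compounds shown alone.

Values in a functional assay on the whole organism for inhibition, with Mus musculus as the target; on this read-out higher numbers stand for an effect only at larger amounts of compound and lower numbers for an effect already at smaller amounts:
- compound 1 `CN1Cc2c(N)cccc2C(c2ccc(Cl)cc2)C1`: 1.1 mg/kg
- compound 2 `CN1Cc2c(N)cccc2C(c2ccc(F)cc2)C1`: 0.25 mg/kg
- compound 3 `CCCNC(=O)Nc1cccc2c1CN(C)CC2c1ccccc1`: > 80 mg/kg

The entry for compound 3 is a limit of the assay and not a number.

Compound 4 `CC(C)NCCC(=O)Nc1cccc2c1CN(C)CC2c1ccccc1` is the next to be read. The change is 2-(isopropylamino)ethyl in place of propylamino on a carbonyl carbon.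

For the measured compounds named here, the one measured step, a 4.4-fold lower number from compound 1 to compound 2 (0.64 log units; beyond the scatter), swaps fluoro for chloro on an aromatic carbon, so it bears only loosely on this change and gives no more than a rough size. Compound 2 at 0.25 mg/kg shows that the shared core can act at small amounts, so a move toward lower numbers in this assay is expected, though with little certainty.

The expected change is an at least 4.0-fold lower number from compound 3 to compound 4 (0.60 log units; beyond the scatter).

For compound 4 the estimated value is 20 mg/kg, with an expected range of 3 mg/kg to 100 mg/kg.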

Compound 4, dose for half-maximal effect: about 125 mg/kg
For compound 4 the middle estimate is 6.3-fold (0.80 log units) below the measured one, outside the stated range (above it).
By their numbers in this assay, from the lowest: compound 2; then compound 1; then compound 4.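

The step from compound 3 to compound 4 cannot be read, as compound 3 carries only a limit of the assay: the limit of > 80 mg/kg in this assay, at which 1 of the 4 values shown sits. The compounds shown leave open whether 2-(isopropylamino)ethyl in place of propylamino on a carbonyl carbon raises or lowers the number at all.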